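Series notes: the step from compound 3 to compound 4

This account rests on a few compounds, and the source may have more. Where it says the series, first, only, none or still open, it means among the compounds named here.

Three measured compounds share one core and differ only in the group carried on the five-membered aromatic ring with 4 nitrogen. Compound 1 `Cc1cc(NC(=O)Cn2nnc(-c3cccnc3)n2)n(C2CCCCC2)n1` gives 96% in an assay on HEK293 cells for activation of Kir3.1/Kir3.2 (Homo sapiens), read by thallium flux; on this read-out lower numbers stand for smaller maximal responses and higher numbers for larger maximal responses. Compound 2 `Cc1cc(NC(=O)Cn2nnc(-c3cccc(Cl)c3)n2)n(C2CCCCC2)n1` gives 89% in this assay, and compound 3 `COc1ccc(-c2nnn(CC(=O)Nc3cc(C)nn3C3CCCCC3)n2)cc1` gives 90%. Compound 3 stands second highest of the three numbers; the nearest is a number 1 percentage points higher from compound 2 to compound 3 (within the scatter), the furthest is a number 6 percentage points lower from compound 1 to compound 3 (within the scatter), and the remaining step is a number 7 percentage points lower from compound 1 to compound 2 (within the scatter). All three steps lie within the scatter, so the three aromatic groups give maximal responses that cannot be told apart.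

Compound 4 `Cc1cc(NC(=O)Cn2nnc(C3CC3)n2)n(C2CCCCC2)n1` differs from compound 3 by cyclopropyl in place of 4-methoxyphenyl on an aromatic carbon. For the measured compounds named here, none of the measured steps covers an exchange of an aromatic group for a non-aromatic one; they show only that swapping one six-membered aromatic ring for another keeps the numbers within the scatter of each other. The step is therefore expected to be a number 10 percentage points lower from compound 3 to compound 4 (within the scatter), with wide uncertainty. Compound 4 is expected to give 80% in this assay. The estimated range for compound 4 runs from 50% to 100%.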

Compound 4, largest response reached (Emax), in percent of the reference or control that the assay uses: > 68%
Compound 4 ended at the assay's limit (the forecaster's own chance of this, stated with the estimate: 0%); the middle value lies beyond the limit too.
By their numbers in this assay, from the lowest: compounds 2, 3 and 1 (each within the scatter of the next).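

In this assay compound 4 gives > 68%, which is a limit of the assay and not a number. For the compounds shown here, no step from compound 1, compound 2 or compound 3 to compound 4 can be read. The compounds shown leave open whether cyclopropyl in place of these aromatic groups changes the maximal response at all.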